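The compounds below may be only part of what the source reports. "The series", "measured", "known", "first", "only" and "open" are said of these compounds alone.

Compound 2 `COc1ccc2[nH]c(-c3nc(-c4ccc(Cl)cc4)no3)cc2c1` sits at the top of the numbers shown: in a functional assay on Jurkat cells (Homo sapiens) for antiproliferative activity, read by WST assay, with a stated time of 72 h (on this read-out higher numbers stand for weaker inhibition and lower numbers for stronger inhibition), compound 2 gives > 50000 nM, which is a limit of the assay and not a number. That is the limit of > 50000 nM in this assay, at which 1 of the 2 values shown sits. For the measured compounds named here, compound 1 `Cc1noc(-c2cc3cc(F)ccc3[nH]2)n1` supplies the one measured value, giving 22900 nM in this assay. Compound 3 `Fc1ccc2[nH]c(-c3nc(-c4ccc(Cl)cc4)no3)cc2c1` differs from compound 2 by fluoro in place of methoxy on an aromatic carbon. Going by the values given here, with no measured step of this kind available, the step is expected to be an at least 1.6-fold lower number from compound 2 to compound 3 (0.22 log units; that floor lies within the scatter), modest and toward a measurable number. Compound 3 is therefore estimated at 30000 nM in this assay, within 8000 nM to 100000 nM.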

Compound 3, half-maximal inhibitory concentration: > 50000 nM
Compound 3: a limit, no number; the forecaster's own chance of this, stated with the estimate: 45%; at least 1.6-fold (0.22 log units) between middle value and limit.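

In this assay compound 3 gives > 50000 nM as a limit of the assay and not a number, so fluoro in place of methoxy on this aromatic carbon does not yield a measurable value with 4-chlorophenyl present. For the compounds shown here, the one readable step, 4-chlorophenyl in place of methyl on an aromatic carbon, is an at least 2.1-fold higher number from compound 1 to compound 3 (0.33 log units; beyond the scatter) with fluoro kept. The step from methoxy to fluoro cannot be read, and the series now gathers at one ceiling: the limit of > 50000 nM in this assay, at which 2 of the 3 values shown sit.

Open, from the compounds shown here alone, is whether an amine or a carboxylic acid in place of 4-chlorophenyl would give a measurable number. Going by these compounds, how methoxy behaves with methyl in that place also remains open.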